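A few compounds are considered here, and "the series" means these few. Any claim that something is new, unique, unknown or untested is made for them only; others in the source may bear on it.

Working notes on the series. In a functional assay on the whole organism for agonist activity, with Mus musculus as the target (a lower number here means that less compound is needed, a higher number that more compound is needed for the effect), compound 1 `CC(=O)NCC#CCn1ccnc1` gives > 100 mg/kg, which is a limit of the assay and not a number. Compound 2 `CC(=O)NCC#CCn1cncc1C` gives > 100 mg/kg, which is likewise only a limit. The position of compound 2 is therefore known only as the limit of > 100 mg/kg in this assay, at which 2 of the 2 values shown sit.

Compound 3 `CC(=O)N(C)CC#CCn1cncc1C` differs from compound 2 by methyl in place of hydrogen on an amide-type nitrogen, in words methyl in place of hydrogen on an amide-type nitrogen. Among the compounds with values here, only one measured step bears on this change: a step that the two limits leave unreadable from compound 1 to compound 2. Within the data shown here, that step also puts methyl in place of hydrogen, but on an aromatic carbon, and no measured step touches the amide-type nitrogen. It therefore supplies neither a size nor a direction to carry over, and the series holds no number to anchor an expectation in this assay. Another limit remains the likeliest report. The expected step, held with little confidence, is a step that the limit leaves unreadable from compound 2 to compound 3. For compound 3 the estimated value is 150 mg/kg, with an expected range from 40 mg/kg to 400 mg/kg.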

Compound 3, dose for half-maximal effect: 45 mg/kg
Compound 3: the middle estimate sits 3.3-fold (0.52 log units) above what was measured, and the stated range covers the measured number.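

In this assay, within the data shown here, methyl in place of hydrogen on the amide-type nitrogen gives an at least 2.2-fold lower number from compound 2 to compound 3 (0.34 log units; beyond the scatter), the first step that can be read, and it shows that this nitrogen is a position where a single added carbon changes the dose needed beyond the scatter. Among these compounds, compound 3 thereby becomes the first compound with a true number rather than a limit, and the change of acetamido to acetyl(methyl)amino gives the series its only measured anchor in this assay. The printed step is only a lower bound on the size of the change, and the true distance stays unknown, because the starting point is not a number: the limit of > 100 mg/kg in this assay, at which 2 of the 3 values shown sit.

From the compounds shown here alone, whether an ethyl group or a longer chain on the same amide-type nitrogen would lower the dose further, hold it or lose the effect stays open, as does whether replacing the acetyl group with a carbamate would keep it. Also open, going by these compounds, is whether the same methyl on the amide-type nitrogen would act alike on the core of compound 1, which lacks the methyl on the aromatic carbon.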